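Series notes: second fluoro on the aryl ring

The source may hold more compounds than are shown below. What is called first, only, known or untested is meant among the compounds shown, and "the series" means these compounds.

The shared core is set out in compound 1, `Cc1cc(NC(=O)Cn2nnc(-c3cccnc3)n2)n(C2CCCCC2)n1`, compound 2, `Cc1cc(NC(=O)Cn2nnc(-c3cccc(Cl)c3)n2)n(C2CCCCC2)n1`, and compound 3, `Cc1cc(NC(=O)Cn2nnc(-c3ccc(F)cc3)n2)n(C2CCCCC2)n1`. In an assay on HEK293 cells for activation of Kir3.1/Kir3.2 (Homo sapiens), read by thallium flux (on this read-out lower numbers stand for an effect already at smaller amounts and higher numbers for an effect only at larger amounts of compound), compound 1 gives 1930 nM, compound 2 gives 300 nM, and compound 3 gives 180 nM. Compound 3 has the lowest of the three numbers; its nearest neighbour is compound 2, and the two lie within the scatter, while the gap to compound 1 is beyond it, as the steps of a 6.4-fold lower number from compound 1 to compound 2 (0.81 log units; beyond the scatter) and an 11-fold lower number from compound 1 to compound 3 (1.03 log units; beyond the scatter) show. The step of a 1.7-fold lower number from compound 2 to compound 3 (0.22 log units; within the scatter) stays within the scatter.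

Compound 4, `Cc1cc(NC(=O)Cn2nnc(-c3ccc(F)c(F)c3)n2)n(C2CCCCC2)n1`, is not yet measured. It differs from compound 3 by fluoro in place of hydrogen on an aromatic carbon. Among the measured compounds shown here, no measured step adds a second fluoro to the aryl ring; the nearest comparison is a 1.7-fold lower number from compound 2 to compound 3 (0.22 log units; within the scatter), which exchanges one halogenated phenyl for another, whereas the larger steps from compound 1 both replace a pyridin-3-yl with a phenyl. A step within the scatter in this assay is therefore expected, in either direction. For compound 4 the estimate in this assay is 150 nM, with a range of 60 nM to 400 nM, which means an expected step of a 1.2-fold lower number from compound 3 to compound 4 (0.08 log units; within the scatter).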

Compound 4, half-maximal effective concentration: 116 nM
Beside the measured number, compound 4's estimate is 1.3-fold (0.11 log units) above it; the measured number falls inside the stated range.
By their numbers in this assay, from the lowest: compounds 4, 3 and 2 (each within the scatter of the next, the first and the last beyond it); then compound 1.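

Adding a second fluoro to compound 3, ortho to the existing fluoro group and meta to a large group, gives the first direct reading at this place on the aryl ring in this assay, and it stays within the scatter (a 1.6-fold lower number from compound 3 to compound 4 (0.19 log units; within the scatter)), so 3,4-difluorophenyl and 4-fluorophenyl cannot be told apart here. The added fluoro is therefore tolerated, and the position shows no clear gain or loss from this change. Compound 4 does separate from the 3-chlorophenyl compound (a 2.6-fold lower number from compound 2 to compound 4 (0.41 log units; beyond the scatter)), a gap that compound 3 did not open, and it remains far from the pyridin-3-yl compound (a 17-fold lower number from compound 1 to compound 4 (1.22 log units; beyond the scatter)), but nothing available explains either step.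

Going by these compounds, whether this place accepts anything other than fluoro remains open, for example a chloro, methoxy, trifluoromethyl or amino group in the position of the new fluoro, and 3-fluorophenyl would show how much the 4-fluoro contributes to the 3,4-difluorophenyl result. On these data alone, all four compounds keep the rest of the shared core constant, so it is also open whether these aryl readings hold when the core changes elsewhere.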